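A few compounds are considered here, and "the series" means these few. Any claim that something is new, unique, unknown or untested is made for them only; others in the source may bear on it.

In a physicochemical assay for solubility, read by HPLC, at pH 7.4 (a higher number here means a more soluble compound, a lower number a less soluble compound), compound 1 (`CCCCCCCc1cc(=O)c2cc([N+](=O)[O-])ccc2[nH]1`) reads < 5000 nM, which is a limit and not a number. Compound 2 (`CCCCCOCc1cc(=O)c2cc([N+](=O)[O-])ccc2[nH]1`) gives 15000 nM, and compound 3 (`CCOCCCCc1cc(=O)c2cc([N+](=O)[O-])ccc2[nH]1`) gives 50000 nM. Compound 4 (`CCCCCCCc1[nH]c2ccc([N+](=O)[O-])cc2c(=O)c1CO`) keeps the heptyl group of compound 1 and carries hydroxymethyl in place of hydrogen on an aromatic carbon. Among the compounds with values here, no measured step touches that carbon. The nearest evidence lies in the chain, where oxygen enters in an at least 3.0-fold higher number from compound 1 to compound 2 (0.47 log units; beyond the scatter) and in an at least 10-fold higher number from compound 1 to compound 3 (1.00 log units; beyond the scatter). Hydroxymethyl also brings oxygen, but the heptyl group stays intact, so only a cautious upward read-across is expected in this assay. The expected step is an at least 1.6-fold higher number from compound 1 to compound 4 (0.20 log units; that floor lies within the scatter). For compound 4 the estimated value is 8000 nM, with an expected range of 2500 nM to 25000 nM.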

Compound 4, solubility: 5000 nM
Compound 4: middle estimate off by 1.6-fold (0.20 log units), on the high side; measured number inside the range.
By their numbers in this assay, from the lowest: compound 4; then compound 2; then compound 3.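

In this assay, within the data shown here, the earlier compounds change only the chain, whereas hydroxymethyl on this aromatic carbon, ortho to a heptyl group, gives a number no lower from compound 1 to compound 4 (the limit leaves the size open) as the only reading at this place. Compound 1 reads < 5000 nM as a limit and not a number. With heptyl kept, any gain from hydroxymethyl therefore has no readable size, and compound 4 stands at that limit: the limit of < 5000 nM in this assay, at which 1 of the 4 values shown sits.

Open, as far as these compounds go, is what hydroxymethyl does on a chain holding oxygen, such as the pentyloxy chain of compound 2. Also open, from the compounds shown here alone, is how an amine or a carboxylic acid on this aromatic carbon would read.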